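A few compounds are considered here, and "the series" means these few. Any claim that something is new, unique, unknown or untested is made for them only; others in the source may bear on it.

Compound 3 `COc1cc(N(C)CCN(C)C)c(NC(=O)/C=C\C(C)C)cc1Nc1nccc(-c2cn(C)c3ccccc23)n1` sets the lower of the two plain numbers in a functional assay on NCI-H1975 cells (Homo sapiens) for antiproliferative activity, read by MTT assay, with a stated time of 72 h (a higher number here means a weaker inhibitor, a lower number a stronger inhibitor), where compound 3 gives 1820 nM. Compound 2 `COc1cc(N(C)CCN(C)C)c(NC(=O)C=C(C)C)cc1Nc1nccc(-c2cn(C)c3ccccc23)n1` gives 5610 nM in this assay. Compound 1 `COc1cc(N(C)CCN(C)C)c(NC(=O)C(Cl)=C(Cl)Cl)cc1Nc1nccc(-c2cn(C)c3ccccc23)n1` reaches only a limit of this assay, > 50000 nM, a value that marks the limit of > 50000 nM in this assay, at which 1 of the 3 values shown sits, rather than a number.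

The next compound, compound 4 `CC/C=C\C(=O)Nc1cc(Nc2nccc(-c3cn(C)c4ccccc34)n2)c(OC)cc1N(C)CCN(C)C`, differs from compound 3 in one place: hydrogen in place of methyl on a saturated chain carbon bound to a double-bonded chain carbon and a saturated chain carbon. Read one bond further out, the isopropyl on the alkene becomes an ethyl.

For the measured compounds named here, three measured steps touch this region. The change from trichlorovinyl to the branched alkene gives an at least 8.9-fold lower number from compound 1 to compound 2 (0.95 log units; beyond the scatter), and to the isopropyl-bearing alkene gives an at least 27-fold lower number from compound 1 to compound 3 (1.43 log units; beyond the scatter). Between the two alkyl-bearing alkenes the difference is a 3.1-fold lower number from compound 2 to compound 3 (0.49 log units; beyond the scatter), so the tail beyond the carbonyl does move the number, though none of these steps removes a single methyl as the step to compound 4 does.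

Compound 4 is therefore expected to sit near compound 3, with a step of a 1.4-fold higher number from compound 3 to compound 4 (0.15 log units; within the scatter) that may fall within the scatter or be a slight weakening. The estimate for compound 4 is 2600 nM, expected to lie between 900 nM and 7500 nM.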

Compound 4, half-maximal inhibitory concentration: 3860 nM
Beside the measured number, compound 4's estimate is 1.5-fold (0.17 log units) below it, and the stated range covers the measured number.
By their numbers in this assay, from the lowest: compound 3; then compounds 4 and 2 (each within the scatter of the next). At a limit, above all of these: compound 1.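

Taking one methyl off the saturated chain carbon, so that isopropyl becomes ethyl, gives a 2.1-fold higher number from compound 3 to compound 4 (0.33 log units; beyond the scatter) in this assay, which shows that this single methyl changes the number by a modest but readable step, and compound 3 keeps the lowest number of the set. The ethyl-bearing tail and the 2-methylprop-1-en-1-yl tail are not told apart, since a 1.5-fold lower number from compound 2 to compound 4 (0.16 log units; within the scatter) lies within the scatter, so the step seen between compound 2 and compound 3 does not extend to every change among these alkyl tails. Compound 1 sits at a limit of the assay rather than at a number, and an at least 12-fold lower number from compound 1 to compound 4 (1.11 log units; beyond the scatter) places the but-1-en-1-yl amide with the other two alkyl-bearing alkenes, clear of the 1,2,2-trichloroethenyl amide.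

The compounds shown leave open how a plain methyl, a longer chain such as n-butyl, or a dimethylamino group on this alkene would read in this assay, so it cannot yet be said whether isopropyl marks a best point or only one step along a trend. Nothing given here accounts for why the methyl matters.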